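Bromo for chloro on the fused ring: an expected small step

The compounds below may be only part of what the source reports. "The series", "measured", "known", "first", "only" and "open" are said of these compounds alone.

Measured compounds:
compound 1 `Nc1sc2c(c1C(=O)c1cccc3ccccc13)CCC2`: 8%
compound 2 `Nc1sc2c(c1C(=O)c1ccc(Cl)c3ccccc13)CCC2`: 0%

In an assay on isolated protein with adenosine receptor A1 (Homo sapiens) as the target, tested at 10 uM (a lower number here means less inhibition, a higher number more inhibition at the concentration tested (going by the name of the read-out)), compound 1 gives 8% and compound 2 gives 0%. Of the two numbers, that of compound 2 is the lower, yet the step of a number 8 percentage points lower from compound 1 to compound 2 (within the scatter) lies within the scatter. Compound 3 `Nc1sc2c(c1C(=O)c1ccc(Br)c3ccccc13)CCC2` differs from compound 2 by bromo in place of chloro on an aromatic carbon. Within the data shown here, the only measured step exchanges hydrogen for a halogen; none exchanges one halogen for another, so it bears on this change only loosely. From that, no step beyond the scatter is expected: a number 3 percentage points higher from compound 2 to compound 3 (within the scatter). Compound 3 is therefore estimated at 3%, between -8% and 15%.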

Compound 3, a percentage reported as inhibition, at one concentration (the size of the read-out at that concentration, not a potency): 0%
Estimate against measurement, compound 3: 3 percentage points above; the range from low to high includes it.
By their numbers in this assay, from the lowest: compounds 2, 3 and 1 (each within the scatter of the next).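

In this assay, among these compounds, the exchange of one halogen for another at this position, para to a large group, gives no change at the digits printed from compound 2 to compound 3 (within the scatter) and is the first such step. Bromo in place of hydrogen gives a number 8 percentage points lower from compound 1 to compound 3 (within the scatter) and so, like chloro, stays within the scatter. No available evidence bears on these steps.

Still open, as far as these compounds go, is whether, in this assay and at this position, an amine, a methoxy group or a carboxylic acid would give a step beyond the scatter. Also open, from the compounds shown here alone, is how any change elsewhere on the shared core would read.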